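A second chloro on compound 1

The compounds below may be only part of what the source reports. "The series", "measured", "known", "first", "only" and "open" are said of these compounds alone.

compound 1 `Clc1ccc2[nH]c(-c3cn(-c4ccccc4)nc3-c3ccccc3)nc2c1` – 3480 nM
compound 2 `Brc1ccc2[nH]c(-c3cn(-c4ccccc4)nc3-c3ccccc3)nc2c1` – 1760 nM
compound 3 `Clc1cc2nc(-c3cn(-c4ccccc4)nc3-c3ccccc3)[nH]c2cc1Cl` – not yet measured

Among the compounds with values here, in a functional assay on HeLa cells (Homo sapiens) for antiproliferative activity, read by MTT assay, with a stated time of 48 h (a lower number here means a stronger inhibitor, a higher number a weaker inhibitor), compound 1 gives 3480 nM and compound 2 gives 1760 nM, so compound 1 stands within the scatter of the only other measured compound. Compound 3 keeps the shared core and the chloro of compound 1, and adds one change chloro in place of hydrogen on an aromatic carbon with chloro in place of hydrogen on an aromatic carbon. Within the data shown here, only one measured step bears on this: a 2.0-fold lower number from compound 1 to compound 2 (0.30 log units; within the scatter), with bromo in place of chloro on an aromatic carbon. That step exchanges one group for another rather than adding one, so it guides the expectation only loosely. In this assay no step beyond the scatter is therefore expected. The estimated step is a 1.3-fold lower number from compound 1 to compound 3 (0.13 log units; within the scatter) and is expected to stay small. For compound 3 the expected value is 2600 nM with an estimated range of 1100 nM to 6000 nM.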

Compound 3, half-maximal inhibitory concentration: 13400 nM
The estimate for compound 3 lay 5.2-fold (0.71 log units) below the measured number; the whole stated range lies below it.
By their numbers in this assay, from the lowest: compounds 2 and 1 (each within the scatter of the next); then compound 3.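

In this assay, the added chloro, on an aromatic carbon ortho to a chloro group, moves the number in the weaker direction by a step beyond the scatter: a 3.9-fold higher number from compound 1 to compound 3 (0.59 log units; beyond the scatter). Within the data shown here, the earlier pair showed only an exchange of one halogen for another, with a step within the scatter, so this is the first sign that the ring tolerates a change less well at this unsubstituted carbon. Nothing given here explains the loss.

The compounds shown leave open whether the loss belongs to chloro itself or would follow any group at this position, such as a methoxy group, an amine or a carboxylic acid. They also leave open whether a smaller atom such as fluoro would be tolerated here.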